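Working notes: from compound 3 to compound 4

The compounds below may be only part of what the source reports. "The series", "measured", "known", "first", "only" and "open" are said of these compounds alone.

Measured in a functional assay on 786-0 cells (Homo sapiens) for inhibition, read by sulforhodamine B assay, with a stated time of 48 h; a higher number here means a weaker inhibitor of growth, a lower number a stronger inhibitor of growth:
- compound 1 `Cc1ccc(-c2c(CNC(C)(C)C)c(C(=O)O)nn2-c2ccccc2)cc1`: > 688000 nM (a limit, not a number)
- compound 2 `CC(C)(C)NCc1c(C(=O)O)nn(-c2ccc(Cl)cc2)c1-c1ccc(F)cc1`: 204000 nM
- compound 3 `CC(C)(C)NCc1c(C(=O)O)nn(-c2ccc(Cl)cc2)c1-c1ccc(Br)cc1`: 542000 nM

Compound 3, at 542000 nM, has the higher of the two true numbers in this assay. Its nearest neighbour is compound 2. Compound 1 has only a limit: the limit of > 688000 nM in this assay, at which 1 of the 3 values shown sits.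

Compound 4 `Cc1ccc(-c2c(CNC(C)(C)C)c(C(=O)O)nn2-c2ccc(Cl)cc2)cc1` has methyl in place of bromo on an aromatic carbon, para to a large group: methyl in place of bromo on an aromatic carbon. This swap has not been measured directly. Within the data shown here, the only measured step at this place is a 2.7-fold higher number from compound 2 to compound 3 (0.42 log units; beyond the scatter), which is modest. Compound 1 also carries 4-methylphenyl, but it offers only a limit.

Among the measured compounds shown here, with a 2.7-fold higher number from compound 2 to compound 3 (0.42 log units; beyond the scatter) as the sole guide, no step beyond the scatter is expected in this assay, although a modest step in either direction remains possible. The expected change is a 1.4-fold lower number from compound 3 to compound 4 (0.13 log units; within the scatter). For compound 4 the estimate is 400000 nM, with an expected range of 170000 nM to 850000 nM.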

Compound 4, concentration for 50% growth inhibition: > 629000 nM
Compound 4: no number, only a limit (the forecaster's own chance of this, stated with the estimate: 30%); at least 1.5-fold (0.19 log units) between middle value and limit.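

In this assay compound 4 gives no number, only a limit: the limit of > 629000 nM in this assay, at which 1 of the 4 values shown sits.

Against bromo, methyl gives an at least 1.1-fold higher number from compound 3 to compound 4 (0.06 log units; that floor lies within the scatter), so this floor does not separate the two groups. Against fluoro, methyl gives an at least 3.0-fold higher number from compound 2 to compound 4 (0.48 log units; beyond the scatter), so both bromo and methyl now stand apart from fluoro in this series with chloro on the other aryl ring, and compound 2 at 204000 nM keeps the only low number among the three.

From the compounds shown here alone, the step from compound 1 to compound 4 cannot be read, so what chloro in place of hydrogen does on that ring stays open. Also open, going by these compounds, is whether a hydroxyl or an amine at the position of the fluoro, bromo and methyl groups would give a lower number than compound 2 in this assay.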